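Bromo in place of fluoro on compound 2

The source may hold more compounds than are shown below. What is called first, only, known or untested is meant among the compounds shown, and "the series" means these compounds.

In a functional assay on MCF7 cells (Homo sapiens) for inhibition, read by sulforhodamine B assay, with a stated time of 48 h (a higher number here means a weaker inhibitor of growth, a lower number a stronger inhibitor of growth), compound 1 `CCOC(=O)c1nn(-c2ccccc2)c(-c2ccc(F)cc2)c1CNC(C)(C)C` gives 306000 nM; 517000 nM (2 entries) across two entries. Compound 2 `CC(C)(C)NCc1c(C(=O)O)nn(-c2ccccc2)c1-c1ccc(F)cc1` stands at > 680000 nM, which is a limit of the assay and not a number. Compound 2 therefore offers no single value from which to measure a step. Compound 3 `CC(C)(C)NCc1c(C(=O)O)nn(-c2ccccc2)c1-c1ccc(Br)cc1` has yet to be measured in this assay.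

The structural change is bromo in place of fluoro on an aromatic carbon, so that 4-fluorophenyl becomes 4-bromophenyl. Going by the values given here, no measured pair isolates a change of this kind, so the step has no direct precedent. The expectation is a step no larger than the usual scatter, with a slight lean towards stronger inhibition of growth. There is also a substantial chance that compound 3 returns only a limit. The expected step is an at least 1.1-fold lower number from compound 2 to compound 3 (0.05 log units; that floor lies within the scatter). Compound 3 is estimated at 600000 nM, with an expected range from 300000 nM to 1000000 nM.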

Compound 3, concentration for 50% growth inhibition: 293000 nM
Estimate against measurement, compound 3: 2.0-fold (0.31 log units) above; measured number outside the range, below it.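

In this assay, the change from 4-fluorophenyl to 4-bromophenyl on the carboxylic acid gives the series its first readable step, an at least 2.3-fold lower number from compound 2 to compound 3 (0.36 log units; beyond the scatter). The aromatic carbon para to a large group is therefore a place where exchanging one halogen for another can move growth inhibition beyond the scatter, which compounds 1 and 2 alone could not show. As far as these compounds go, the true size of the step remains unknown and the printed figure is only a floor, because the value for compound 2 is a limit of the assay and not a number: the limit of > 680000 nM in this assay, at which 1 of the 3 values shown sits.

From the compounds shown here alone, how chloro, iodo or methoxy at the same place would compare with bromo stays open, so the step cannot yet be tied to any trend across substituents. Also open, going by these compounds, is whether 4-bromophenyl would lower the number in the same way on the ethyl ester, where compound 1 gives 306000 nM; 517000 nM (2 entries) in this assay, and the spread of those two entries would have to be considered in reading any such step.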